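Fluoro to Methyl on Compound 3

A few compounds are considered here, and "the series" means these few. Any claim that something is new, unique, unknown or untested is made for them only; others in the source may bear on it.

In a functional assay on NALM-6 cells (Homo sapiens) for cytotoxicity, read by luminescence and CellTiter-Glo, with a stated time of 3 days (a higher number here means a weaker inhibitor, a lower number a stronger inhibitor), compound 1 (`O=C(Nc1cc(C(F)(F)F)cc(C(F)(F)F)c1)c1ccc(-c2ccccc2)cc1O`) gives 1580 nM and compound 2 (`O=C(Nc1cc(Cl)cc(Cl)c1)c1cc(F)ccc1O`) gives 1440 nM with no gap between them beyond the scatter. Compound 3 (`N#Cc1ccc(NC(=O)c2ccc3cccnc3c2O)c(F)c1`) stands lowest of the three at 370 nM and is the strongest inhibitor among them, with both other numbers higher by more than the scatter. Compound 1 and compound 2 each differ from compound 3 in more than one place, so none of these comparisons shows what a single swap is worth.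

Compound 4 (`Cc1cc(C#N)ccc1NC(=O)c1ccc2cccnc2c1O`) keeps everything in compound 3 except one group. It carries methyl in place of fluoro on an aromatic carbon and this carbon lies ortho to a large group and meta to a cyano group. Among the compounds with values here, no measured pair isolates this swap, so the expectation in this assay is of no step beyond the scatter, with at most a slight drift toward a weaker number. The expected size of the change is a 1.2-fold higher number from compound 3 to compound 4 (0.09 log units; within the scatter) and this remains an estimate. Compound 4 is estimated at 450 nM with a range of 150 nM to 1300 nM for the coming measurement.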

Compound 4, half-maximal inhibitory concentration: 230 nM
The estimate for compound 4 lay 2.0-fold (0.29 log units) above the measured number; the measured number falls inside the stated range.
By their numbers in this assay, from the lowest: compounds 4 and 3 (each within the scatter of the next); then compounds 2 and 1 (each within the scatter of the next).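

In this assay, the swap gives the only single-place reading among the compounds shown: a 1.6-fold lower number from compound 3 to compound 4 (0.21 log units; within the scatter), a step within the scatter, so this position, ortho to a large group and meta to a cyano group, holds either methyl or fluoro with no change that can be told from repeat measurement. Compound 1 and compound 2 could not give this reading, as each differs from compound 3 in more than one place, and their gaps to compound 3 say nothing about this carbon. No measured evidence bears on the result, and the pair alone gives no account of why the two groups read alike.

Going by these compounds, it remains open whether the number would stay in the same band with another group on this carbon, such as an amine, a methoxy group, a chlorine or a longer chain like propyl. On these data alone, it is equally open whether methyl in place of fluoro would read the same way if the cyano group were exchanged for a carboxylic acid, or on the core of compound 1 or compound 2.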